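Removing the azido group from an N-hydroxy cytosine dideoxynucleoside

The source may report more compounds than this note shows. Statements on the series, on what has been measured and on what is new or still open speak of the compounds shown alone.

Compound 1, `[N-]=[N+]=N[C@@H]1C[C@@H](n2ccc(NO)nc2=O)O[C@H]1CO`: 2000000 nM
Compound 2, `O=c1nc(NO)ccn1[C@@H]1C=C[C@H](CO)O1`: 3500000 nM
Compound 3, `Cc1cn([C@@H]2C=C[C@H](CO)O2)c(=O)nc1N`: 600000 nM

In an ADME assay on HL-60 cells (Homo sapiens) for cytotoxicity, read by MTT assay, with a stated time of 3 days (a lower number here means that less compound is tolerated, a higher number that more compound is tolerated), compound 1 gives 2000000 nM, the second highest of the three numbers. Compound 2 gives 3500000 nM, which lies within the scatter of compound 1. Compound 3 gives 600000 nM, a lower number beyond the scatter. Compound 4, `O=c1nc(NO)ccn1[C@@H]1CC[C@H](CO)O1`, has not been measured. It differs from compound 1 in one place: hydrogen in place of azido on a saturated ring carbon. Within the data shown here, no measured pair shows this change, so its size cannot be read from the data. Since the azido group alone leaves and a hydrogen enters, the step from compound 1 to compound 4 in this assay is expected to stay within the scatter, a 1.3-fold lower number from compound 1 to compound 4 (0.12 log units; within the scatter). Compound 4 is therefore estimated to give about 1500000 nM, between 400000 nM and 5000000 nM.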

Compound 4, half-maximal cytotoxic concentration: 1600000 nM
Beside the measured number, compound 4's estimate is 1.1-fold (0.03 log units) below it, within the range that was stated.
By their numbers in this assay, from the lowest: compound 3; then compounds 4, 1 and 2 (each within the scatter of the next, the first and the last beyond it).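

In this assay, among these compounds, hydrogen in place of azido on a saturated ring carbon gives a 1.3-fold lower number from compound 1 to compound 4 (0.10 log units; within the scatter) and thus provides the first direct reading of this position. For this read-out, the azido group can leave the core of compound 1 without a shift beyond the scatter. Nothing available explains this result.

From the compounds shown here alone, whether other groups at this ring carbon, such as a fluorine atom or an amine, would also stay within the scatter remains open. The compounds shown also leave open whether this step would hold with a different group on the shared core.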